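The source may hold more compounds than are shown below. What is called first, only, known or untested is meant among the compounds shown, and "the series" means these compounds.

In a functional assay on A549 cells (Homo sapiens) for antiproliferative activity, read by MTT assay, with a stated time of 72 h (a lower number here means a stronger inhibitor, a higher number a weaker inhibitor), compound 1 `O=C(Nc1ccc(Cl)c(-c2nnc3c(Cl)cccn23)c1)c1ccc(C(F)(F)F)cc1Cl` returns only a limit, > 100000 nM, so no number is in hand for it. Compound 2 `O=C(Nc1ccc(Cl)c(-c2nnc3c(Cl)cccn23)c1)c1ccc(F)cc1Cl`, which carries fluoro in place of trifluoromethyl on an aromatic carbon, likewise gives in this assay only a limit, > 100000 nM. The step from compound 1 to compound 2 in this assay, a step that the two limits leave unreadable from compound 1 to compound 2, cannot be read because both values sit at the limit of > 100000 nM in this assay, at which 2 of the 2 values shown sit. Compound 3 `O=C(Nc1ccc(Cl)c(-c2nnc3c(Cl)cccn23)c1)c1ccc(C(F)(F)F)cc1F` differs from compound 1 by fluoro in place of chloro on an aromatic carbon, ortho to a large group and meta to a trifluoromethyl group. Going by the values given here, the one measured step concerns a different group and is itself unreadable, so these numbers set no size or direction for the step in this assay beyond the scatter; what the two values show is that neither compound reached a measurable potency. Compound 3 is therefore expected in this assay to give 100000 nM, within 30000 nM to 300000 nM, most likely again reported as a limit. The estimated step from compound 1 to compound 3 in this assay is a number no higher from compound 1 to compound 3 (the limit leaves the size open), expected to be none beyond the scatter.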

Compound 3, half-maximal inhibitory concentration: > 100000 nM
Compound 3 gave a limit, no number (the forecaster's own chance of this, stated with the estimate: 85%); the middle value sits exactly at the limit.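

The step from compound 1 to compound 3 in this assay cannot be read, because both compounds return only a limit and no number: (the limit of > 100000 nM in this assay, at which 3 of the 3 values shown sit). The compounds shown therefore leave open the size and direction of either exchange on the aromatic carbon in this assay, with no measured potency among them.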